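Truncation of the pyrrolidine to a bare acetamide arm

The source may report more compounds than this note shows. Statements on the series, on what has been measured and on what is new or still open speak of the compounds shown alone.

Going by the values given here, compound 2 `NC(=O)[C@@H]1CCCN1Cc1cc(=O)oc2cc(OCc3ccccc3)ccc12` gives 35000 nM in an assay (strain Wistar) for inhibition of Amine oxidase [flavin-containing] A (Rattus norvegicus) (a higher number here means a weaker inhibitor, a lower number a stronger inhibitor), the lower of the two numbers measured so far; compound 1 `NC(=O)[C@@H]1CCCN1c1cc(=O)oc2cc(OCc3ccccc3)ccc12` gives 99800 nM. Among the compounds with values here, the only measured step, a 2.9-fold lower number from compound 1 to compound 2 (0.46 log units; beyond the scatter), concerns the linker and not the ring. Compound 3 `NC(=O)Cc1cc(=O)oc2cc(OCc3ccccc3)ccc12` carries carbamoyl in place of 2-carbamoylpyrrolidin-1-yl on a saturated chain carbon bound to an aromatic carbon. Within the data shown here, no measured step addresses removal of this ring, so the direction is open; a modest weakening is the working assumption. For compound 3 the estimate is 60000 nM, with a range of 20000 nM to 200000 nM. This expected change corresponds to a 1.7-fold higher number from compound 2 to compound 3 (0.23 log units; within the scatter).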

Compound 3, half-maximal inhibitory concentration: 8000 nM
Compound 3: the middle estimate sits 7.5-fold (0.88 log units) above what was measured; measured number outside the range, below it.
By their numbers in this assay, from the lowest: compound 3; then compound 2; then compound 1.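

The 2-carbamoylpyrrolidin-1-yl group is not required on this saturated chain carbon in this assay: carbamoyl in its place gives (a 4.4-fold lower number from compound 2 to compound 3 (0.64 log units; beyond the scatter)), so neither the ring nor its defined stereocentre is needed for this level of inhibition. Carbamoylmethyl in place of 2-carbamoylpyrrolidin-1-yl on an aromatic carbon gives the largest step in the series (a 12-fold lower number from compound 1 to compound 3 (1.10 log units; beyond the scatter)). No supporting data explain either step.

As far as these compounds go, the role of the carbamoyl group itself remains open. A carboxylic acid or an amine in its place, or a longer chain carrying it, would test this.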